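The source may report more compounds than this note shows. Statements on the series, on what has been measured and on what is new or still open speak of the compounds shown alone.

Compound 1 `O=C(NO)c1ccc(/C=C/c2ccnc(-c3ccccc3O)c2)cc1`: 1420 nM
Compound 2 `O=C(NO)c1ccc(/C=C/c2ccnc(-c3ccc(C(F)(F)F)cc3)c2)cc1`: > 10000 nM (a limit of the assay, not a number)

Going by the values given here, in a functional assay on MGC-803 cells (Homo sapiens) for antiproliferative activity, read by CellTiter-Glo, with a stated time of 72 h (on this read-out lower numbers stand for stronger inhibition and higher numbers for weaker inhibition), compound 1 gives 1420 nM and stands as the only numeric value in the set. Compound 2 sits at the limit of > 10000 nM in this assay, at which 1 of the 2 values shown sits. Compound 3 `O=C(NO)c1ccc(/C=C/c2ccncc2)cc1` differs from compound 1 by hydrogen in place of 2-hydroxyphenyl on an aromatic carbon. Among the compounds with values here, no measured step covers this change, so its size cannot be read from the data; a step beyond the scatter toward weaker inhibition in this assay seems the more probable outcome, though one within the scatter cannot be excluded. Compound 3 is expected to give 4000 nM, with a range of 1200 nM to 13000 nM. This estimate means an expected step of a 2.8-fold higher number from compound 1 to compound 3 (0.45 log units; beyond the scatter).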

Compound 3, half-maximal inhibitory concentration: 3930 nM
The estimate for compound 3 lay 1.0-fold (0.01 log units) above the measured number; measured number inside the range.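

Replacing 2-hydroxyphenyl with hydrogen on this aromatic carbon, next to the ring nitrogen, gives in this assay a 2.8-fold higher number from compound 1 to compound 3 (0.44 log units; beyond the scatter). Going by these compounds alone, the step is the first measured effect at this position: the 2-hydroxyphenyl group accompanies stronger inhibition here, yet it is not needed for a measurable value, as compound 3 gives 3930 nM.

The compounds shown leave open how much of the step belongs to the hydroxyl and how much to the ring, which a plain phenyl at this carbon would separate. From the compounds shown here alone, how an amine at this carbon would compare also remains open.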